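Swapping a methylphenyl for thiophene on a sulfonamide

A few compounds are considered here, and "the series" means these few. Any claim that something is new, unique, unknown or untested is made for them only; others in the source may bear on it.

Measured compounds:
Compound 1, `CCOC(=O)c1oc2ccc(NS(=O)(=O)c3cccc(C)c3)cc2c1C`, 101000 nM
Compound 2, `CCOC(=O)c1oc2ccc(NS(=O)(=O)c3ccc(OC)c(OC)c3)cc2c1C`, 52000 nM

Both compounds share one core and differ only in the ring attached to the sulfonyl group. In a functional assay on MCF7 cells (Homo sapiens) for antiproliferative activity, read by MTT assay, with a stated time of 72 h (a higher number here means a weaker inhibitor, a lower number a stronger inhibitor), compound 1 gives 101000 nM, while compound 2 gives 52000 nM. These two numbers lie within the usual scatter of each other, so compound 1 cannot be told apart from compound 2 on this evidence; both are weak inhibitors.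

Compound 3, `CCOC(=O)c1oc2ccc(NS(=O)(=O)c3cccs3)cc2c1C`, has not yet been tested in this assay. It differs from compound 1 as follows: thiophen-2-yl in place of 3-methylphenyl on a sulfonyl sulfur. For the measured compounds named here, no measured pair shows what such a swap does here, so there is no basis for expecting a step beyond the scatter in either direction. The number for compound 3 is therefore expected to stay close to that of compound 1, with the step of a 1.1-fold lower number from compound 1 to compound 3 (0.05 log units; within the scatter) as the estimate. Compound 3 is expected to give about 90000 nM, within a range of 35000 nM to 250000 nM.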

Compound 3, half-maximal inhibitory concentration: 92300 nM
The estimate for compound 3 lay 1.0-fold (0.01 log units) below the measured number; the range from low to high includes it.
By their numbers in this assay, from the lowest: compounds 2, 3 and 1 (each within the scatter of the next).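

In this assay, for the compounds shown here, the only pair here that differs in one place shows a 1.1-fold lower number from compound 1 to compound 3 (0.04 log units; within the scatter) when thiophen-2-yl takes the place of 3-methylphenyl on a sulfonyl sulfur. On this evidence, a five-membered aromatic ring with one sulfur and a six-membered aromatic ring of carbon only cannot be told apart at this position, and compound 3 remains a weak inhibitor like compound 1. No measurement shown gives a reason for this result.

Still open, going by these compounds, is whether a ring carrying an amine or a carboxylic acid on this sulfonyl sulfur would move the number beyond the scatter. Also open, on these data alone, is whether a change elsewhere, such as a carboxylic acid in place of the ethyl ester, would do so.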